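This account rests on a few compounds, and the source may have more. Where it says the series, first, only, none or still open, it means among the compounds named here.

Measured so far:
Compound 1, `CCCCc1nc(C(C)C)c(CC(=O)OC)c(=O)n1Cc1ccc(-c2ccccc2-c2noc(=O)[nH]2)cc1`, gives 10.5% in an ADME assay on microsomes from liver (Homo sapiens) for metabolic stability, with a stated time of 30 min; on this read-out lower numbers stand for a less stable compound and higher numbers for a more stable compound.
Compound 2, `CCCCc1nc(C(C)C)c(CC(=O)OCC(F)(F)F)c(=O)n1Cc1ccc(-c2ccccc2-c2noc(=O)[nH]2)cc1`, is recorded as "not determined" (no result reported) in this assay, so it has no result there.

Compound 2 thus stands without a single number in this assay; the only measured point here is compound 1, whose read-out of 10.5% is a low fraction remaining. Compound 3, `CCCCc1nc(C(C)C)c(CC(=O)OCCC)c(=O)n1Cc1ccc(-c2ccccc2-c2noc(=O)[nH]2)cc1`, is to be measured and differs from compound 2 by ethyl in place of trifluoromethyl on a saturated chain carbon bound to an oxygen next to a carbonyl group. As compound 2 carries no number, the step from compound 2 to compound 3 cannot be sized against a measurement; compound 1, which shares the core of compound 3, is the only anchor. Among the measured compounds shown here, compound 3 is therefore expected to stay on the low side, near what compound 1 shows at 10.5%, with no step in this assay beyond the scatter anticipated against that reference. Compound 3 is estimated at 12%, within a range from 2% to 35%.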

Compound 3, percent of the compound remaining: 7.2%
The estimate for compound 3 lay 4.8 percentage points above the measured number; the range from low to high includes it.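

In this assay, among the compounds shown here, ethyl in place of hydrogen on a saturated chain carbon bound to an oxygen next to a carbonyl group gives a number 3.3 percentage points lower from compound 1 to compound 3 (within the scatter) and so provides the first measured step at this position. Across this step the two compounds are not separated beyond the scatter, and both compound 1 and compound 3 keep only a low share of compound remaining. No measurement at hand bears on what lies behind this result.

Going by these compounds, the step from compound 2 to compound 3 cannot be read, so the effect of trifluoromethyl at this place remains unknown. On these data alone, whether a longer chain, an amine or a carboxylic acid on this saturated chain carbon would move the read-out beyond the scatter also stays open.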